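The source may report more compounds than this note shows. Statements on the series, on what has been measured and on what is new or still open speak of the compounds shown alone.

Series notes, a functional assay on Hep 3B2 cells (Homo sapiens) for antiproliferative activity, read by MTT assay, with a stated time of 24 h, tested at 0.41 ug/mL; on this read-out lower numbers stand for a weaker effect and higher numbers for a stronger effect at the one concentration tested. Compound 1 `Cc1ccc2nc(C(=O)Nc3c(F)cc(-c4cccc(F)c4)cc3F)c(C)c(O)c2c1` gives 5.25% in this assay. Compound 2 `Cc1c(C(=O)Nc2c(F)cc(-c3cccc(F)c3)cc2F)nc2ccc(F)cc2c1O` gives 4.85%, and compound 3 `Cc1c(C(=O)Nc2c(F)cc(-c3cccc(F)c3)cc2F)nc2ccc(F)cc2c1C(=O)O` gives 1.06%. The number of compound 3 lies within the usual scatter of the numbers of compound 2 and of compound 1, so nothing sets compound 3 apart among the three; all three read-outs sit low at the one concentration tested. Compound 4 `COc1ccc2nc(C(=O)Nc3c(F)cc(-c4cccc(F)c4)cc3F)c(C)c(C(=O)O)c2c1` is not yet measured and differs from compound 3 as follows: methoxy in place of fluoro on an aromatic carbon. The measured step that most nearly bears on this exchange is a number 0.4 percentage points lower from compound 1 to compound 2 (within the scatter), a swap of a small group at the same aromatic carbon. The other step, a number 3.8 percentage points lower from compound 2 to compound 3 (within the scatter), touches a different place and a different kind of group. Neither exchange reached beyond the scatter. The expected step is a number 1.9 percentage points higher from compound 3 to compound 4 (within the scatter), none beyond the scatter. Compound 4 is therefore estimated at 3%, with a range from 0% to 12%.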

Compound 4, a percentage reported as inhibition, at one concentration (the size of the read-out at that concentration, not a potency): 0.68%
For compound 4 the middle estimate is 2.3 percentage points above the measured one, within the range that was stated.
By their numbers in this assay, from the lowest: compounds 4, 3, 2 and 1 (each within the scatter of the next).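

Exchanging fluoro for methoxy on this aromatic carbon gives in this assay a number 0.4 percentage points lower from compound 3 to compound 4 (within the scatter). This extends the earlier reading to a larger group that carries a hydrogen-bond acceptor and to compounds with carboxy rather than hydroxy on the shared core: methyl, fluoro and methoxy have now each stood at this carbon, and neither exchange between them reaches beyond the scatter. No measurement is available to explain this result.

From the compounds shown here alone, it remains open whether an amine or a longer chain such as butoxy at this carbon would produce a step beyond the scatter. Also open is whether methoxy would read the same way with hydroxy in place of carboxy, since the fluoro-to-methoxy exchange is shown only with carboxy present.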